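From methylamino to methoxy: one small swap

The source may report more compounds than this note shows. Statements on the series, on what has been measured and on what is new or still open speak of the compounds shown alone.

Going by the values given here, in a physicochemical assay for lipophilicity, read by HPLC, at pH 7.5 (on this read-out lower numbers stand for lower lipophilicity and higher numbers for higher lipophilicity), compound 3 (`CC[C@@H](Nc1c(C#N)c(-c2ccc(-c3ccccc3NC)cc2)nc2cnccc12)C(N)=O`) reads 2.5 and holds the lowest of the three numbers measured so far. On the same scale compound 1 (`CC[C@@H](Nc1c(C#N)c(-c2ccc(-c3cccc(C)c3F)cc2)nc2cnccc12)C(N)=O`) stands at 3 and compound 2 (`CCOc1ccccc1-c1ccc(-c2nc3cnccc3c(N[C@H](CC)C(N)=O)c2C#N)cc1`) at 3 and these two cannot be told apart, as the step between them shows: no change at the digits printed from compound 1 to compound 2 (within the scatter).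

Compound 4 (`CC[C@@H](Nc1c(C#N)c(-c2ccc(-c3ccccc3OC)cc2)nc2cnccc12)C(N)=O`) comes from compound 3 by a single change, methoxy in place of methylamino on an aromatic carbon. Among the compounds with values here, no compound with methoxy has been measured yet, and the nearest evidence is the step that put methylamino where ethoxy stood: a number 0.50 log units lower from compound 2 to compound 3 (beyond the scatter). The step from the 2-fluoro-3-methylphenyl group to 2-(methylamino)phenyl was of the same size: a number 0.50 log units lower from compound 1 to compound 3 (beyond the scatter).

Methoxy resembles the ethoxy of compound 2 at 3 in attaching through oxygen, and that resemblance is the whole basis for the expectation here. Undoing most of that modest drop, an upward move is expected, estimated as a number 0.40 log units higher from compound 3 to compound 4 (beyond the scatter) in this assay for this swap. For compound 4 the estimated value is 2.9 with a range from 2.5 to 3.3 until the measurement arrives.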

Compound 4, distribution coefficient: 2.7
Compound 4: middle estimate off by 0.20 log units, on the high side, and the stated range covers the measured number.
By their numbers in this assay, from the lowest: compounds 3, 4, 1 and 2 (each within the scatter of the next, the first and the last beyond it).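

In this assay, methoxy on this aromatic carbon cannot be told apart from methylamino (a number 0.20 log units higher from compound 3 to compound 4 (within the scatter)) or from ethoxy, which carries one more methyl (a number 0.30 log units lower from compound 2 to compound 4 (within the scatter)), and the whole 2-methoxyphenyl group cannot be told apart from 2-fluoro-3-methylphenyl (a number 0.30 log units lower from compound 1 to compound 4 (within the scatter)). The earlier compounds shown here showed only a clear gap between ethoxy and methylamino; the methoxy compound now splits that gap into two smaller steps, each within the scatter, while the two ends stay beyond it. The swap also takes away the one hydrogen-bond donor that methylamino brings, and on this read-out that exchange gives no step beyond the scatter.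

Nothing measured on these groups bears on what lies behind these numbers. The compounds shown leave open how a hydroxyl, a plain amine, a dimethylamino group or a longer chain such as propoxy would read on this same aromatic carbon.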